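Shortening the chain and dropping the phenyl cap

The source may report more compounds than this note shows. Statements on the series, on what has been measured and on what is new or still open speak of the compounds shown alone.

Measured compounds:
compound 1, `CCCCCCCCCCCCCCCCCC(=O)C(F)(F)F`, 6400 nM
compound 2, `O=C(CCCCCCCCc1ccccc1)c1nc2ncccc2o1`, 0.1 nM
compound 3, `O=C(CCCCCCCc1ccccc1)C(F)(F)F`, 2000 nM

In an assay on isolated protein for inhibition of Fatty-acid amide hydrolase 1 (Homo sapiens), read by radioligand binding (a lower number here means a stronger inhibitor, a higher number a weaker inhibitor), compound 3 gives 2000 nM. Among the three measured compounds this is the second highest number. Its nearest neighbour is compound 1, whose 6400 nM is higher, a gap beyond the scatter. Compound 2 lies far away at the other end: its 0.1 nM is the lowest number by a wide margin.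

Compound 4 is `CCCCCCCCCC(=O)C(F)(F)F`. It differs from compound 3 in one place: ethyl in place of phenyl on a saturated chain carbon, seven bonds along the chain from a carbonyl carbon. Both compounds keep the carbonyl bearing the trifluoromethyl group, so the change is confined to the far end of the chain.

No pair of measured compounds separated by a single change is available, so the size of the step has to be judged from what is shown. Compound 1, a plain saturated chain, sits higher than compound 3, and compound 2, whose chain ends in a phenyl, sits far lower. On that basis the loss of the phenyl in compound 4 is expected to move the number upward in this assay, by a step beyond the scatter but modest in size. The step from compound 3 to compound 4 is expected to be a 7.5-fold higher number from compound 3 to compound 4 (0.88 log units; beyond the scatter). Compound 4 is therefore estimated at 15000 nM, within a range from 4000 nM to 60000 nM.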

Compound 4, half-maximal inhibitory concentration: 10000 nM
Compound 4: the middle estimate sits 1.5-fold (0.18 log units) above what was measured, and the stated range covers the measured number.
By their numbers in this assay, from the lowest: compound 2; then compound 3; then compounds 1 and 4 (each within the scatter of the next).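

Within the data shown here, compound 4 gives the first direct reading at this position in this assay: ethyl in place of phenyl, on a saturated chain carbon seven bonds along the chain from a carbonyl carbon, produces (a 5.0-fold higher number from compound 3 to compound 4 (0.70 log units; beyond the scatter)), a modest step beyond the scatter. With the carbonyl bearing the trifluoromethyl group unchanged, the phenyl is not needed for compound 4 to give a number in this assay, although the phenyl-capped compound 3 has the lower value. No measured property or other supporting observation accompanies this step, so the data leave its size unexplained.

From the compounds shown here alone, it remains open whether a methyl, a cyclohexyl ring or a pyridine ring at the end of the chain would give a number nearer that of compound 3 or that of compound 4, and whether a longer chain ending in phenyl would change the picture. Also open, going by these compounds, is whether the same exchange of phenyl for ethyl would give a step of similar size on the core of compound 2, which carries no trifluoromethyl group.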